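Exchanging the amine substituent of compound 2: an estimate

The compounds below may be only part of what the source reports. "The series", "measured", "known", "first", "only" and "open" are said of these compounds alone.

Compound 1 `CCO/C(O)=C1\C(C)=NC(COCCNc2n[nH]c(N)n2)=C(C(=O)OC)C1c1cccc(Cl)c1Cl`: 100 nM
Compound 2 `CCO/C(O)=C1\C(COCCNc2noc(N)n2)=NC(C)=C(C(=O)OC)C1c1cccc(Cl)c1Cl`: 3.16 nM

Of the compounds shown here, two built on the same core have so far been tested in a functional assay (aorta) with Rattus norvegicus as the target; a higher number here means a weaker inhibitor, a lower number a stronger inhibitor. Compound 1 gives 100 nM. Compound 2 gives 3.16 nM, the lower of the two numbers, and its gap to compound 1 lies well beyond the usual scatter. The two compounds differ from each other in more than one place, so no single structural step can be read from that pair.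

Compound 3 `CCO/C(O)=C1\C(COCCNc2cc(Cl)ncn2)=NC(C)=C(C(=O)OC)C1c1cccc(Cl)c1Cl` has not yet been measured. It is made from compound 2 by one change: 6-chloropyrimidin-4-yl in place of 5-amino-1,2,4-oxadiazol-3-yl on an amine nitrogen. For the measured compounds named here, nothing among the measured compounds shows how this assay responds to such an exchange, so the expectation rests on the standing of compound 2 alone. A modest weakening is expected, a step from compound 2 to compound 3 of about a 3.2-fold higher number from compound 2 to compound 3 (0.50 log units; beyond the scatter), larger than scatter but not by much. For compound 3 the expected value in this assay is 10 nM, with a range from 2 nM to 50 nM.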

Compound 3, half-maximal inhibitory concentration: 12.6 nM
Compound 3: the middle estimate sits 1.3-fold (0.10 log units) below what was measured; the measured number falls inside the stated range.
By their numbers in this assay, from the lowest: compound 2; then compound 3; then compound 1.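

In this assay, for the compounds shown here, this is the first exchange on the shared core that can be read as a single change: putting 6-chloropyrimidin-4-yl in place of 5-amino-1,2,4-oxadiazol-3-yl on the amine nitrogen gives a 4.0-fold higher number from compound 2 to compound 3 (0.60 log units; beyond the scatter), a modest step beyond the scatter. The position therefore accepts quite a different group at a modest cost in this read-out: a six-membered aromatic ring with 2 hetero atoms, a chlorine and 0 hydrogen-bond donors replaces a five-membered aromatic ring with 3 hetero atoms and 1 hydrogen-bond donor. Since the ring, its hetero atoms, the chlorine and the amino group all differ at once, and no supporting measurement is available, this single step cannot be divided among those differences.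

An unsubstituted pyrimidin-4-yl group would show what the chlorine contributes, while a 6-aminopyrimidin-4-yl group would restore an amino group on the six-membered ring. Also open, going by these compounds, is how much of the ring is needed at all, which a simple acetyl group on the same amine nitrogen would begin to test.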